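The compounds below may be only part of what the source reports. "The series", "measured", "known", "first", "only" and "open" are said of these compounds alone.

Compound 1 `CC[C@@H]1C(=O)N(C)c2cnc(-n3ccc4cc(C(=O)NCC(C)C)ccc43)nc2N1C1CCCC1` and compound 2 `CC[C@@H]1C(=O)N(C)c2cnc(-n3ccc4cc(C(=O)NC5CCCC5)ccc43)nc2N1C1CCCC1` share one core and differ only in the group on an amide-type nitrogen. In a functional assay on HeLa cells (Homo sapiens) for antiproliferative activity, read by CCK-8 assay, with a stated time of 72 h (on this read-out higher numbers stand for weaker inhibition of growth and lower numbers for stronger inhibition of growth), compound 1 gives 3280 nM, whereas compound 2 gives 247 nM, the lower of the two numbers shown; the single measured step, a 13-fold lower number from compound 1 to compound 2 (1.12 log units; beyond the scatter), came with cyclopentyl in place of isobutyl at that position. Compound 3 `CCCCNC(=O)c1ccc2c(ccn2-c2ncc3c(n2)N(C2CCCC2)[C@H](CC)C(=O)N3C)c1` is not yet measured, and differs from compound 2 by butyl in place of cyclopentyl on an amide-type nitrogen. Within the data shown here, the only step that bears on this change is the one from compound 1 to compound 2, in which a branched chain gave way to a ring and the number fell markedly; returning to an open chain, this time butyl, is therefore expected to push the number back up, though how far a straight chain matches the branched one is unknown. For compound 3 in this assay the expected step is a 6.1-fold higher number from compound 2 to compound 3 (0.78 log units; beyond the scatter), giving an estimate of 1500 nM with a likely range from 500 nM to 5000 nM.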

Compound 3, concentration for 50% growth inhibition: 346 nM
Compound 3: middle estimate off by 4.3-fold (0.64 log units), on the high side, outside the stated range (below it).
By their numbers in this assay, from the lowest: compounds 2 and 3 (each within the scatter of the next); then compound 1.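

In this assay, butyl in place of cyclopentyl on the amide-type nitrogen gives a 1.4-fold higher number from compound 2 to compound 3 (0.15 log units; within the scatter), so a ring at this position is not required for a number in this range. Butyl in place of isobutyl, one open chain for another, gives a 9.5-fold lower number from compound 1 to compound 3 (0.98 log units; beyond the scatter), so among these three compounds the isobutyl group of compound 1 stands apart, and the earlier step cannot be read as a simple contrast between rings and open chains. No available evidence explains why these two open chains differ.

The compounds shown leave open how a longer chain such as hexyl, a smaller ring such as cyclopropyl, or a chain ending in an amine or a carboxylic acid would compare at this nitrogen. They also leave open whether the gap between isobutyl and butyl would persist on a different core.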